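Aryl swap on the hydrazone series: compound 3 to compound 4

The source may report more compounds than this note shows. Statements on the series, on what has been measured and on what is new or still open speak of the compounds shown alone.

Values from a functional assay on HCT-116 cells (Homo sapiens) for antiproliferative activity, read by MTT assay (on this read-out lower numbers stand for stronger inhibition and higher numbers for weaker inhibition), follow
- compound 1 `Cc1cccc(/C=N/Nc2ncc3c(n2)n(C2CCCC2)c(=O)c(=O)n3C)c1` gives > 100000 nM (a limit of the assay, not a number)
- compound 2 `Cn1c(=O)c(=O)n(C2CCCC2)c2nc(N/N=C/c3ccc(F)c(Cl)c3)ncc21` gives 9020 nM
- compound 3 `Cn1c(=O)c(=O)n(C2CCCC2)c2nc(N/N=C/c3ccc(O)c(F)c3)ncc21` gives 59300 nM

Compound 3 at 59300 nM holds the higher of the two actual numbers. Within the data shown here, the gap to its only numeric neighbour is a 6.6-fold higher number from compound 2 to compound 3 (0.82 log units; beyond the scatter) and is modest.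

Compound 4 `Cn1c(=O)c(=O)n(C2CCCC2)c2nc(N/N=C/c3ccc(C(F)(F)F)cc3)ncc21` has not yet been measured. It carries 4-(trifluoromethyl)phenyl in place of 3-fluoro-4-hydroxyphenyl on a carbon with a double bond to nitrogen, and the count runs 4-(trifluoromethyl)phenyl in place of 3-fluoro-4-hydroxyphenyl on a carbon with a double bond to nitrogen in full.

All three measured steps change this same group, so all bear on the question. The closest guide is compound 2, and a 6.6-fold higher number from compound 2 to compound 3 (0.82 log units; beyond the scatter) suggests that leaving 3-fluoro-4-hydroxyphenyl could give a lower number. Compound 1 goes against this pattern, with an at least 1.6-fold lower number from compound 1 to compound 3 (0.22 log units; that floor lies within the scatter) as its step and an at least 11-fold lower number from compound 1 to compound 2 (1.04 log units; beyond the scatter) showing how widely this group alone can move the result. A modest step towards stronger inhibition in this assay is therefore expected, with a wide margin.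

The expected step is a 3.3-fold lower number from compound 3 to compound 4 (0.52 log units; beyond the scatter) as the working estimate. Compound 4 is estimated at 18000 nM in this assay with an expected range from 5000 nM to 60000 nM for now.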

Compound 4, half-maximal inhibitory concentration: 29000 nM
The estimate for compound 4 lay 1.6-fold (0.21 log units) below the measured number; measured number inside the range.
By their numbers in this assay, from the lowest: compound 2; then compound 4; then compound 3. At a limit, above all of these: compound 1.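

With a group carrying no hydrogen-bond donor or acceptor, a 2.0-fold lower number from compound 3 to compound 4 (0.31 log units; beyond the scatter) in this assay, yet a 3.2-fold higher number from compound 2 to compound 4 (0.51 log units; beyond the scatter), so the loss of the hydroxyl-bearing 3-fluoro-4-hydroxyphenyl does not by itself match the 3-chloro-4-fluorophenyl of compound 2. All three groups that carry fluorine now give numbers that differ beyond the scatter, which shows that fluorine alone does not set the read-out at this carbon, and the 3-methylphenyl of compound 1 is the only group shown without a halogen, with an at least 3.4-fold lower number from compound 1 to compound 4 (0.53 log units; beyond the scatter) giving only a floor. Compound 1 gives > 100000 nM, a limit of the assay and not a number: the limit of > 100000 nM in this assay, at which 1 of the 4 values shown sits.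

The compounds shown do not separate the effect of the trifluoromethyl group from that of its place on the phenyl ring, since no other group is paired with it in a single change. As far as these compounds go, whether an amine, a carboxylic acid or a longer chain on this phenyl ring would give a number below that of compound 2 stays open, as does whether the order of these groups holds with anything other than the cyclopentyl group on the shared core.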